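A second trifluoromethyl on compound 1

The source may hold more compounds than are shown below. What is called first, only, known or untested is meant among the compounds shown, and "the series" means these compounds.

In a functional assay on COLO 205 cells (Homo sapiens) for inhibition, read by sulforhodamine B assay, with a stated time of 48 h (a higher number here means that more compound is tolerated, a lower number that less compound is tolerated), compound 1 (`O=C(Nc1cccc(-n2cc(-c3ccncc3)c(-c3ccc(Cl)c(O)c3)n2)c1)Nc1cccc(C(F)(F)F)c1`) gives > 32500 nM, which is a limit and not a number. Compound 1 therefore stands at the limit of > 32500 nM in this assay, at which 1 of the 3 values shown sits.

Compound 4 (`O=C(Nc1cccc(-n2cc(-c3ccncc3)c(-c3ccc(Cl)c(O)c3)n2)c1)Nc1cc(C(F)(F)F)cc(C(F)(F)F)c1`) differs from compound 1 in one place: trifluoromethyl in place of hydrogen on an aromatic carbon. The new trifluoromethyl sits on an aromatic carbon, meta to a trifluoromethyl group. Among the compounds with values here, no measured compound carries this exact change.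

The closest guide is compound 3 (`O=C(Nc1cccc(-n2cc(-c3ccncc3)c(-c3ccc(Cl)c(O)c3)n2)c1)Nc1ccc(Cl)c(Cl)c1`), which gives 22700 nM and has 3,4-dichlorophenyl in place of 3-(trifluoromethyl)phenyl on an amide-type nitrogen. Within the data shown here, that swap amounts to an at least 1.4-fold lower number from compound 1 to compound 3 (0.15 log units; that floor lies within the scatter), so the one measured change at this group gives no firm size or direction. Compound 2 (`COc1cc(-c2nn(-c3cccc(NC(=O)Nc4ccc(Cl)c(Cl)c4)c3)cc2-c2ccncc2)ccc1Cl`) gives 3140 nM. Its step, a 7.2-fold higher number from compound 2 to compound 3 (0.86 log units; beyond the scatter), is the larger one but concerns methyl on an oxygen, a part that compound 4 leaves as in compound 1, so it bears little on this change.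

No step beyond the scatter is therefore expected, and any shift would most likely be towards a lower number. The expected step is an at least 1.3-fold lower number from compound 1 to compound 4 (0.11 log units; that floor lies within the scatter), and a result that is again only a limit remains quite possible. The estimate for compound 4 is 25000 nM, with an expected range of 9000 nM to 32500 nM.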

Compound 4, concentration lethal to 50% of the cells: 2920 nM
Compound 4: the middle estimate sits 8.6-fold (0.93 log units) above what was measured; the measured number lies below the stated range.
By their numbers in this assay, from the lowest: compounds 4 and 2 (each within the scatter of the next); then compound 3. At a limit, above all of these: compound 1.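

The added trifluoromethyl on compound 1 gives, in this assay, an at least 11-fold lower number from compound 1 to compound 4 (1.04 log units; beyond the scatter), so this position, meta to a trifluoromethyl group, is one where a single added group moves the number well beyond the scatter. The earlier step at this ring, an at least 1.4-fold lower number from compound 1 to compound 3 (0.15 log units; that floor lies within the scatter), gave no firm size or direction, whereas this change fixes the direction at this carbon as towards less compound tolerated. The size of the step is only a floor, since compound 1 stands at a limit and not a number: the limit of > 32500 nM in this assay, at which 1 of the 4 values shown sits.

From the compounds shown here alone, whether the shift belongs to trifluoromethyl itself or would follow from other groups on the same aromatic carbon remains open, and a nitrile, a methoxy group or an amine there would help to separate these cases. Also open, going by these compounds, is whether the same change carries over when the oxygen on the other aromatic ring bears a methyl, as in compound 2, and the values shown give no reason for the shift.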